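This account rests on a few compounds, and the source may have more. Where it says the series, first, only, none or still open, it means among the compounds named here.

The study concerns four dichloroacetamides built on an aromatic amine, three measured and one still awaiting its number. Compound 1 `CCOc1ccccc1-c1cc(NC(=O)C(Cl)Cl)cc(-c2ccccc2OCC)c1` carries two ethoxy-bearing aryl groups on the shared core, and in a functional assay on KB 3-1 cells (Homo sapiens) for cytotoxicity, read by MTT assay, with a stated time of 68 h (on this read-out higher numbers stand for weaker inhibition and lower numbers for stronger inhibition), compound 1 gives 8730 nM. Compound 3 `CCOc1cccc(-c2cc(NC(=O)C(Cl)Cl)cc(-c3cccc(OCC)c3)c2)c1` is a closely related bis-aryl compound, and in this assay compound 3 gives 14800 nM. Compound 2 `O=C(Nc1cccc(-c2ccccn2)c1)C(Cl)Cl` bears a single pyridin-2-yl group instead. In this assay compound 2 reaches only a limit, > 50000 nM, and no number is known for it. On the numbers shown, compound 2 therefore stands at the limit of > 50000 nM in this assay, at which 1 of the 3 values shown sits, the only one of the three compounds to do so.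

Compound 4 `O=C(Nc1cccc(-c2ccccc2)c1)C(Cl)Cl` differs from compound 2 in one place: phenyl in place of pyridin-2-yl on an aromatic carbon. Among the measured compounds shown here, no step between two measured compounds is available to calibrate this change, so only a cautious expectation can be offered. Since the starting point is itself a limit, a step in this assay from compound 2 to compound 4 of moderate size toward stronger inhibition is expected, though one no larger than the scatter remains entirely possible. The estimate for compound 4 is 40000 nM, with a range from 10000 nM to 150000 nM, which corresponds to an expected step of an at least 1.2-fold lower number from compound 2 to compound 4 (0.09 log units; that floor lies within the scatter).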

Compound 4, half-maximal inhibitory concentration: 46800 nM
Beside the measured number, compound 4's estimate is 1.2-fold (0.07 log units) below it; measured number inside the range.
By their numbers in this assay, from the lowest: compounds 1 and 3 (each within the scatter of the next); then compound 4. At a limit, above all of these: compound 2.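

In this assay, phenyl in place of pyridin-2-yl on an aromatic carbon, meta to a ((dichloromethyl)carbonyl)amino group, gives an at least 1.0-fold lower number from compound 2 to compound 4 (0.02 log units; that floor lies within the scatter). With phenyl at this position, compound 4 gives a measured number, 46800 nM, so this single-aryl series now has a numerical value at this position, which compound 2 could not supply. The step can be read only as a floor, and it does not show that this change moves the read-out beyond the scatter, because compound 2 stands at a limit and not at a number: the limit of > 50000 nM in this assay, at which 1 of the 4 values shown sits.

Going by these compounds, it therefore remains open how large the true difference between pyridin-2-yl and phenyl is at this position, and whether it exceeds the scatter at all. Also open is how the position responds to other groups in place of phenyl, such as an amine, a carboxylic acid or a methoxy group, and the compounds shown give no single-place step that links compound 4 to compound 1 or compound 3.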